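This account rests on a few compounds, and the source may have more. Where it says the series, first, only, none or still open, it means among the compounds named here.

Two compounds in the series carry numbers in a functional assay on HT-29 cells (Homo sapiens) for cytotoxicity, read by MTT assay, with a stated time of 72 h; a higher number here means a weaker inhibitor of growth, a lower number a stronger inhibitor of growth. Compound 1 `CSc1ccc(CNc2nc(SC)nc3ncccc23)cc1` gives 7030 nM. For the measured compounds named here, compound 2 `CSc1nc(NCCCCc2ccccc2)c2ccccc2n1` differs from compound 1 in more than one place, so no single step links the two and only the pair of values can be set side by side. In this assay compound 2 returns > 100000 nM, which is a limit of the assay and not a number. Compound 2 therefore stands at the limit of > 100000 nM in this assay, at which 1 of the 2 values shown sits, with nothing known about how far past it the true value lies.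

Compound 3 `CSc1nc(NCCCCCO)c2ccccc2n1` has not yet been measured in this assay. Its change from compound 2 is hydroxymethyl in place of phenyl on a saturated chain carbon, four bonds along the chain from a nitrogen on an aromatic ring. Going by the values given here, no step between measured compounds is recorded, so there is no measured precedent for what this change does here, and compound 2 supplies no number to anchor it. The step is expected to come out as a number no higher from compound 2 to compound 3 (the limit leaves the size open), that is none the assay would resolve beyond its scatter, with a substantial chance that compound 3 again reaches only the limit. Compound 3 is estimated at 100000 nM, with a range from 30000 nM to 300000 nM.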

Compound 3, concentration for total growth inhibition: > 100000 nM
Compound 3: no number, only a limit (the forecaster's own chance of this, stated with the estimate: 65%); the middle value lies on the limit itself.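

Compound 2 and compound 3 both return only a limit of the assay in this assay, so no step can be read between them: the limit of > 100000 nM in this assay, at which 2 of the 3 values shown sit.

The compounds shown leave open whether hydroxymethyl in place of phenyl on a saturated chain carbon changes growth inhibition at all, and how far past the limit either true value lies.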